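A few compounds are considered here, and "the series" means these few. Any claim that something is new, unique, unknown or untested is made for them only; others in the source may bear on it.

Two compounds share one core and differ only in the group attached to the outer aromatic ring. Compound 1 `O=C(N[C@H]1CNC1=O)OCc1ccc(OC2CCCCC2)cc1` carries a cyclohexyloxy group there, and in an assay on HEK293 cells for inhibition of N-acylethanolamine-hydrolyzing acid amidase (Homo sapiens), read by fluorescence, with stated times of 10 min and 50 min (on this read-out lower numbers stand for stronger inhibition and higher numbers for weaker inhibition), compound 1 gives 2070 nM. Compound 2 `O=C(N[C@H]1CNC1=O)OCc1ccc(-c2cccnc2)cc1` carries a pyridin-3-yl group instead, and in this assay compound 2 gives 8110 nM. Going by the values given here, the single change between them, a 3.9-fold higher number from compound 1 to compound 2 (0.59 log units; beyond the scatter), is therefore a loss of potency. Among the compounds with values here, on the numbers available, compound 2 stands as the weaker of the two, with compound 1 the only neighbour.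

The next compound, compound 3 `CCc1ccc(COC(=O)N[C@H]2CNC2=O)cc1`, differs from compound 2 in one place: ethyl in place of pyridin-3-yl on an aromatic carbon. Within the data shown here, no measured step replaces a pyridin-3-yl with an ethyl, so the only guide is that changing this group moved the number noticeably once before, in a 3.9-fold higher number from compound 1 to compound 2 (0.59 log units; beyond the scatter). Without a closer precedent the expectation is cautious: compound 3 is estimated to stay near compound 2, with a 1.2-fold higher number from compound 2 to compound 3 (0.09 log units; within the scatter) as the expected step. The estimate for compound 3 in this assay is 10000 nM, expected to fall between 3000 nM and 30000 nM.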

Compound 3, half-maximal inhibitory concentration: 160 nM
Compound 3: the middle estimate sits 63-fold (1.80 log units) above what was measured, and the stated range ends above it.
By their numbers in this assay, from the lowest: compound 3; then compound 1; then compound 2.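

Going by these compounds alone, this position, para to a large group, responds far more strongly than the one earlier step could show: in this assay, ethyl in place of pyridin-3-yl gives a 51-fold lower number from compound 2 to compound 3 (1.70 log units; beyond the scatter), and ethyl in place of cyclohexyloxy gives a 13-fold lower number from compound 1 to compound 3 (1.11 log units; beyond the scatter). Both steps are large and beyond the scatter, so among these three compounds, the ethyl of compound 3, which has no ring, gives the strongest inhibition, whereas the earlier pair compared only two groups that each contain a ring. Why ethyl does so much better cannot be told from these numbers, and no measurement bearing on the cause is at hand.

The compounds shown leave open how the number changes with chain length, since a methyl or a longer chain such as propyl or butyl in this place would show whether ethyl stands out or is one point on a trend. They also leave open whether a ring itself is the disadvantage, a question that a cyclopropyl or a plain phenyl in the same place could help to settle.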